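Replacing the Methylcyclopropyl Amide with a Plain Acetyl Group

The source may report more compounds than this note shows. Statements on the series, on what has been measured and on what is new or still open speak of the compounds shown alone.

Three compounds built on one shared core carry a 2-methylcyclopropyl group on the amide carbonyl and differ only in the configuration drawn at its two stereocentres. In an assay on CHO cells for agonist activity at Neuronal acetylcholine receptor; alpha3/beta4 (Homo sapiens), read by FLIPR and calcium flux (on this read-out lower numbers stand for an effect already at smaller amounts and higher numbers for an effect only at larger amounts of compound), compound 1 `C[C@H]1C[C@H]1C(=O)N1CC2CNCC2C1` gives 10000 nM. Compound 2 `C[C@@H]1C[C@@H]1C(=O)N1CC2CNCC2C1` gives 1400 nM in this assay. Compound 3 `C[C@H]1C[C@@H]1C(=O)N1CC2CNCC2C1` gives 34000 nM in this assay, the highest number of the three, so it is the weakest of the set. The steps among them are a 7.1-fold lower number from compound 1 to compound 2 (0.85 log units; beyond the scatter), a 3.4-fold higher number from compound 1 to compound 3 (0.53 log units; beyond the scatter) and a 24-fold higher number from compound 2 to compound 3 (1.39 log units; beyond the scatter). Compound 4 `CC(=O)N1CC2CNCC2C1` removes the three-membered ring altogether: methyl in place of 2-methylcyclopropyl on a carbonyl carbon. Going by the values given here, none of the measured steps mirrors this change; all three concern only how the 2-methylcyclopropyl group is oriented, yet together they show that orientation alone spans a wide range of numbers. Among the compounds with values here, with the methyl those stereocentres vanish, and no measured pair shows what a smaller acyl group does here, so the direction of the step is open. Compound 4 is expected to land between the measured extremes, and the expected step is a 4.3-fold lower number from compound 3 to compound 4 (0.63 log units; beyond the scatter). The estimate for compound 4 is 8000 nM, within a range from 1500 nM to 40000 nM.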

Compound 4, half-maximal effective concentration: 23000 nM
For compound 4 the middle estimate is 2.9-fold (0.46 log units) below the measured one; low and high end bracket the measured number.
By their numbers in this assay, from the lowest: compound 2; then compound 1; then compounds 4 and 3 (each within the scatter of the next).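

In this assay, the effect of the plain methyl depends on which form of the 2-methylcyclopropyl group it replaces: there is a 1.5-fold lower number from compound 3 to compound 4 (0.17 log units; within the scatter), which is no real change, but also a 2.3-fold higher number from compound 1 to compound 4 (0.36 log units; beyond the scatter) and a 16-fold higher number from compound 2 to compound 4 (1.22 log units; beyond the scatter). So a 2-methylcyclopropyl group on this carbonyl carbon does not by itself give a lower number than methyl: compound 1 and compound 2 do better than compound 4, with compound 2 far ahead, whereas compound 3, with the same atoms and bonds, cannot be told apart from compound 4. The information available on these compounds gives no measured reason why methyl matches one form of the ring and falls behind the other two.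

The compounds shown leave open whether the methyl on the three-membered ring is needed at all, which a plain cyclopropyl group on the same carbonyl carbon would help to settle. They also leave open whether an open chain such as ethyl or propyl, or an acyl group carrying an amine, could match compound 2 or give an even lower number.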